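A few compounds are considered here, and "the series" means these few. Any claim that something is new, unique, unknown or untested is made for them only; others in the source may bear on it.

In a functional assay on A2780 cells (Homo sapiens) for antiproliferative activity, read by resazurin assay, with a stated time of 72 h (a higher number here means a weaker inhibitor, a lower number a stronger inhibitor), compound 3 (`CN(Cc1ccccc1)C(=O)c1cc2c(Cc3ccccc3Cl)n[nH]c2cc1O`) stands as "not determined" (no result reported) and so gives no number to start from. Moving to compound 4 (`Cc1cccc(Cc2n[nH]c3cc(O)c(C(=O)N(C)Cc4ccccc4)cc23)c1`) makes one change, 3-methylphenyl in place of 2-chlorophenyl on a saturated chain carbon bound to an aromatic carbon with 3-methylphenyl in place of 2-chlorophenyl on a saturated chain carbon bound to an aromatic carbon. Going by the values given here, the only measured step, a 3.4-fold higher number from compound 1 to compound 2 (0.53 log units; beyond the scatter) for ethyl in place of bromo on an aromatic carbon, concerns different groups and is only a loose guide. Without a number for compound 3, no size or direction of step can be expected. The expectation rests instead on compound 1 (`CN(Cc1ccc(Br)cc1)C(=O)c1cc2c(Cc3ccccc3)n[nH]c2cc1O`) at 2800 nM and compound 2 (`CCc1ccc(CN(C)C(=O)c2cc3c(Cc4ccccc4)n[nH]c3cc2O)cc1`) at 9400 nM in this assay alone. Compound 4 is expected near 5000 nM with an estimated range from 1500 nM to 16000 nM in this test.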

Compound 4, half-maximal inhibitory concentration: 490 nM
Compound 4: the middle estimate sits 10-fold (1.01 log units) above what was measured; the measured number lies below the stated range.
By their numbers in this assay, from the lowest: compound 4; then compound 1; then compound 2.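

In this assay, going by these compounds alone, compound 3 has no number, so no step to compound 4 can be read. The compounds shown leave open how 2-chlorobenzyl and 3-methylbenzyl compare on the shared core. No further data explain the result for compound 4.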